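From a 4-bromophenyl amide to a 3-methoxyphenyl amide

The compounds below may be only part of what the source reports. "The series", "measured", "known", "first", "only" and "open" are said of these compounds alone.

Compound 1 `CN(C)C(=O)c1cc2cnc(Nc3ccc(NC(=O)C4(C(=O)Nc5ccc(Cl)cc5)CC4)cc3)nc2n1C1CCCC1` gives 22.8%
Compound 2 `CN(C)C(=O)c1cc2cnc(Nc3ccc(NC(=O)C4(C(=O)Nc5ccccc5F)CC4)cc3)nc2n1C1CCCC1` gives 85.2%
Compound 3 `CN(C)C(=O)c1cc2cnc(Nc3ccc(NC(=O)C4(C(=O)Nc5ccc(Br)cc5)CC4)cc3)nc2n1C1CCCC1` gives 21.1%

These three compounds share one core and differ only in the aromatic group on an amide-type nitrogen. All were tested in a functional assay on T47D cells (Homo sapiens) for inhibition, read by CCK-8 assay, with a stated time of 72 h, tested at 1 uM; a lower number here means less inhibition of growth, a higher number more inhibition of growth at the concentration tested. There, compound 3 stands at 21.1% and cannot be told apart from compound 1, as the step of a number 1.7 percentage points lower from compound 1 to compound 3 (within the scatter) shows. Compound 2 stands far from both, with a step of a number 64.1 percentage points lower from compound 2 to compound 3 (beyond the scatter).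

Compound 4 `COc1cccc(NC(=O)C2(C(=O)Nc3ccc(Nc4ncc5cc(C(=O)N(C)C)n(C6CCCC6)c5n4)cc3)CC2)c1` brings a new group to that nitrogen: 3-methoxyphenyl in place of 4-bromophenyl on an amide-type nitrogen, (3-methoxyphenyl in place of 4-bromophenyl on an amide-type nitrogen). Within the data shown here, no measured compound carries a 3-methoxyphenyl group, so the data offer only indirect guidance. Compound 2 shows, through the step of a number 62.4 percentage points higher from compound 1 to compound 2 (beyond the scatter), that a different aromatic group here can shift the result greatly. Compounds 1 and 3, both low, carry their halogen in the same place, and compound 4 does not share that arrangement. Among the measured compounds shown here, a rise in this assay is therefore expected, though smaller than the one seen with compound 2, and with wide uncertainty. The expected step is a number 23.9 percentage points higher from compound 3 to compound 4 (beyond the scatter). Compound 4 is estimated at 45%, with an expected range from 18% to 80%.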

Compound 4, percent growth inhibition at one concentration: 56.3%
Compound 4: the middle estimate sits 11.3 percentage points below what was measured; the range from low to high includes it.
By their numbers in this assay, from the lowest: compounds 3 and 1 (each within the scatter of the next); then compound 4; then compound 2.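

Among these compounds, the earlier compounds all carried a halogen on the phenyl ring, so compound 4 is the first sign that a group without one can do well on this amide-type nitrogen: in this assay the step of a number 35.2 percentage points higher from compound 3 to compound 4 (beyond the scatter) and the step of a number 33.5 percentage points higher from compound 1 to compound 4 (beyond the scatter) set it clear of the two low compounds. It still falls short of the 2-fluorophenyl compound, as the step of a number 28.9 percentage points lower from compound 2 to compound 4 (beyond the scatter) shows, so this position now gives three separate levels of growth inhibition rather than only low and high. Across these four compounds the 4-chlorophenyl and 4-bromophenyl groups sit low while the 2-fluorophenyl and 3-methoxyphenyl groups sit higher, with none going against that split, but the set is small and no measurement here explains the ranking.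

Compound 4 changes both the substituent and where it sits on the ring in a single move, so the compounds shown cannot separate those two changes; a 4-methoxyphenyl group and a 3-bromophenyl group would pull them apart. An unsubstituted phenyl group would also show how much any substituent on this ring matters at all.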